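Fluoro for Bromo at the Para Position, Cytotoxicity Expected

A few compounds are considered here, and "the series" means these few. Any claim that something is new, unique, unknown or untested is made for them only; others in the source may bear on it.

Measured compounds:
compound 1, `COc1ccc(-c2cnc(NC(=O)c3ccccc3O)n2C)cc1`: > 100000 nM
compound 2, `Cn1c(-c2ccc(Br)cc2)cnc1NC(=O)c1ccc(F)cc1`: 46000 nM

Compound 1 reaches only a limit in a toxicity assay on THP-1 cells (Homo sapiens) for inhibition (a higher number here means that more compound is tolerated, a lower number that less compound is tolerated), and so gives no number, its value being > 100000 nM. For the measured compounds named here, compound 2 is the one compound with an actual number in this assay, where compound 2 gives 46000 nM. Compound 3, `Cn1c(-c2ccc(F)cc2)cnc1NC(=O)c1ccc(F)cc1`, has not yet been measured. It differs from compound 2 in one place: fluoro in place of bromo on an aromatic carbon. Going by the values given here, no step between two measured compounds that differ in a single place is available, so this change has no precedent within the set. A step from compound 2 to compound 3 of a 1.5-fold higher number from compound 2 to compound 3 (0.18 log units; within the scatter) is expected, small and toward more compound being tolerated, and it may well fall within the scatter of repeated measurements. Compound 3 is estimated at 70000 nM, with a range from 30000 nM to 160000 nM, and a fair chance that only a limit is reported.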

Compound 3, half-maximal cytotoxic concentration: > 100000 nM
Compound 3: a limit, no number; the forecaster's own chance of this, stated with the estimate: 30%; at least 1.4-fold (0.15 log units) between middle value and limit.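

In this assay, for the compounds shown here, the exchange of 4-bromophenyl for 4-fluorophenyl gives the first step in the set that can be read, an at least 2.1-fold higher number from compound 2 to compound 3 (0.33 log units; beyond the scatter). A single halogen exchange on an aromatic carbon, para to a large group, is thus enough to separate compound 2, which gives an actual number, from compound 3, which reaches only a limit. The step gives a minimum size and no full size, because the result for compound 3 is a limit and not a number: the limit of > 100000 nM in this assay, at which 2 of the 3 values shown sit.

From the compounds shown here alone, how far the true value of compound 3 lies from that limit remains open. So does whether chloro, methyl or an amine at the same place would give a number, or whether the same exchange would read alike with another group on the amide side.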